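A few compounds are considered here, and "the series" means these few. Any claim that something is new, unique, unknown or untested is made for them only; others in the source may bear on it.

Compound 1 `CCCCCCCCn1cc(COC2(C(F)(F)F)Oc3ccccc3C=C2C(=O)OCC)nn1` gives > 150000 nM in a functional assay on A549 cells (Homo sapiens) for inhibition, read by MTT assay, with a stated time of 24 h (on this read-out lower numbers stand for stronger inhibition and higher numbers for weaker inhibition), which is a limit of the assay and not a number.
Compound 2 `CCOC(=O)C1=Cc2ccccc2OC1(OCc1cc(-c2ccc3ccccc3c2)no1)C(F)(F)F` gives > 150000 nM in this assay, again a limit.
Compound 3 `O=C(O)C1=Cc2ccccc2OC1(OCc1cc(-c2ccc3ccccc3c2)no1)C(F)(F)F` gives > 150000 nM in this assay, again a limit.

Compound 1 therefore stands only at a limit, as do the other two values shown (the limit of > 150000 nM in this assay, at which 3 of the 3 values shown sit). Among the measured compounds shown here, the one measured step, a step that the two limits leave unreadable from compound 2 to compound 3, is unreadable, since both its ends sit at that limit. Compound 4 `CCOC(=O)C1=Cc2ccccc2OC1(OCc1cn(CC(=O)Nc2ccc(I)cc2Cl)nn1)C(F)(F)F` differs from compound 1 by (2-chloro-4-iodophenyl)carbamoyl in place of heptyl on a saturated chain carbon bound to an aromatic nitrogen. For the measured compounds named here, no measured step bears on this change, and nothing among the three compounds points in either direction beyond the scatter. In this assay compound 4 is therefore expected to sit near the same limit, with an estimated step of a number no higher from compound 1 to compound 4 (the limit leaves the size open). The estimate for compound 4 is 150000 nM, between 40000 nM and 600000 nM.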

Compound 4, half-maximal inhibitory concentration: 22300 nM
Estimate against measurement, compound 4: 6.7-fold (0.83 log units) above, and the stated range ends above it.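

In this assay, the side chain on this saturated chain carbon bound to an aromatic nitrogen can clearly affect the read-out: the change to (2-chloro-4-iodophenyl)carbamoyl gives an at least 6.7-fold lower number from compound 1 to compound 4 (0.82 log units; beyond the scatter). Compound 4 is the only compound shown that gives a number and not a limit, so the size of this step has only a lower bound. The other compounds remain at the assay limit: the limit of > 150000 nM in this assay, at which 3 of the 4 values shown sit.

As far as these compounds go, it remains open whether the step depends on the chlorine, the iodine or the amide hydrogen, and what an unsubstituted phenylcarbamoyl group would give here. Also open, from the compounds shown here alone, is how a carboxylic acid in place of the ethyl ester of compound 4 would read.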